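The compounds below may be only part of what the source reports. "The series", "measured", "known", "first", "only" and "open" are said of these compounds alone.

Measured so far:
Compound 1 `COc1cc(/C=C/C(C)=O)ccc1OCc1cn(-c2ccnc3cc(Cl)ccc23)nn1` gives 3.6 in a physicochemical assay for lipophilicity, read by HPLC, at pH 7.4; on this read-out lower numbers stand for lower lipophilicity and higher numbers for higher lipophilicity.
Compound 2 `COc1ccc(C(=O)/C=C/c2cc(CN3CCN(c4ccnc5cc(Cl)ccc45)CC3)c(O)c(OC)c2)c(OC)c1` gives 5 in this assay.
Compound 3 `COc1cc(/C=C/C(C)=O)ccc1OCCNc1ccnc2cc(Cl)ccc12` gives 3 in this assay.

Compound 1 stands second highest of the three numbers in this assay. Its nearest neighbour is compound 3, whose number lies lower by a gap beyond the scatter; furthest is compound 2, whose number lies higher, again beyond the scatter. None of these pairs differs in a single place, so the values are read only as they stand.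

Compound 4 `COc1ccc(C(=O)/C=C/c2ccc(OCc3cn(-c4ccnc5cc(Cl)ccc45)nn3)c(OC)c2)c(OC)c1` has not yet been measured in this assay. It departs from compound 1 by 2,4-dimethoxyphenyl in place of methyl on a carbonyl carbon. The change enters the heavy atoms and the aromatic ring counted there; an upward step beyond the scatter is expected. The number of compound 2, 5, shows that the high region is reached within this set. For compound 4 the expected step is a number 1.20 log units higher from compound 1 to compound 4 (beyond the scatter), giving an estimate of 4.8, between 4.2 and 5.4.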

Compound 4, distribution coefficient: 4.3
Estimate against measurement, compound 4: 0.50 log units above; measured number inside the range.
By their numbers in this assay, from the lowest: compound 3; then compound 1; then compound 4; then compound 2.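

Replacing methyl with 2,4-dimethoxyphenyl on a carbonyl carbon gives, in this assay, a number 0.70 log units higher from compound 1 to compound 4 (beyond the scatter). For the compounds shown here, compounds 1 and 4 form the first pair in the set that differs in one place, so this position can now be read directly: the larger aryl ketone moves the read-out upward, in a step of modest size, on the core of compound 1. No supporting measurement accounts for the size of this step, so it stands as an observation from a single pair.

The compounds shown leave open whether the step follows the aromatic ring itself or its methoxy groups, which a plain phenyl on the same carbonyl carbon would separate, and how an amine or a carboxylic acid would read in this place. They also leave open whether the same change on compound 3 would give a step of similar size.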